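A few compounds are considered here, and "the series" means these few. Any claim that something is new, unique, unknown or untested is made for them only; others in the source may bear on it.

Compound 1 `CCCCC(C#CC(=O)OC)O/C=C/C(=O)OC` gives 240 nM
Compound 2 `CCCCCCC(C#CC(=O)OC)O/C=C/C(=O)OC` gives 3300 nM
Compound 3 `COC(=O)C#CC(O/C=C/C(=O)OC)C1CCCCC1` gives 2100 nM

In a functional assay on SW1573 cells (Homo sapiens) for antiproliferative activity, read by sulforhodamine B assay, with a stated time of 48 h (a lower number here means a stronger inhibitor of growth, a higher number a weaker inhibitor of growth), compound 3 gives 2100 nM as the second highest of the three numbers. The gap to its nearest neighbour is a 1.6-fold lower number from compound 2 to compound 3 (0.20 log units; within the scatter) and the gap to its furthest is an 8.8-fold higher number from compound 1 to compound 3 (0.94 log units; beyond the scatter) on the other side.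

Compound 4 `COC(=O)C#CC(O/C=C/C(=O)OC)C(C)(C)C` has tert-butyl in place of cyclohexyl on a saturated chain carbon bound to an oxygen on an unsaturated carbon and a triple-bonded carbon. Going by the values given here, no measured step covers tert-butyl itself. The closest guide is compound 1 with its butyl group, and the move from it to cyclohexyl is an 8.8-fold higher number from compound 1 to compound 3 (0.94 log units; beyond the scatter) in size, much like the lengthening of the chain (a 14-fold higher number from compound 1 to compound 2 (1.14 log units; beyond the scatter)). Tert-butyl is branched, unlike butyl, so only part of that gap is expected to be recovered. A modest step to a lower number is therefore expected in this assay (a 2.3-fold lower number from compound 3 to compound 4 (0.37 log units; beyond the scatter)). Compound 4 is estimated at 900 nM with an expected range from 250 nM to 3000 nM in this estimate.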

Compound 4, concentration for 50% growth inhibition: 3000 nM
Estimate against measurement, compound 4: 3.3-fold (0.52 log units) below, and the stated range covers the measured number.
By their numbers in this assay, from the lowest: compound 1; then compounds 3, 4 and 2 (each within the scatter of the next).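

In this assay, tert-butyl on a saturated chain carbon bound to an oxygen on an unsaturated carbon and a triple-bonded carbon reads like the cyclohexyl and hexyl groups: a 1.4-fold higher number from compound 3 to compound 4 (0.15 log units; within the scatter) and a 1.1-fold lower number from compound 2 to compound 4 (0.04 log units; within the scatter) both stay within the scatter, while a 13-fold higher number from compound 1 to compound 4 (1.10 log units; beyond the scatter) is large. Among these four compounds, a branched group without a ring, a ring and a longer straight chain therefore give matching numbers, and only compound 1 with its butyl group stands apart, so neither the ring nor the added chain length is needed for the weaker numbers. Nothing at hand explains why butyl differs from the other three groups.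

The compounds shown leave open whether propyl or pentyl at this place would match butyl or the other three groups. From the compounds shown here alone, a phenyl group there also remains open.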